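The compounds below may be only part of what the source reports. "The series", "measured", "known", "first", "only" and "open" are said of these compounds alone.

Measured so far in a functional assay on HCT-15 cells (Homo sapiens) for inhibition, read by MTT assay, with a stated time of 72 h; on this read-out lower numbers stand for stronger inhibition and higher numbers for weaker inhibition:
Compound 1 `COc1ccc(CCCNCc2c(OC)cc(Oc3ccc(Nc4ccccc4)cc3)cc2OC)cc1`: 2180 nM
Compound 2 `COc1cc(Oc2cccc(Nc3ccccc3)c2)cc(OC)c1CNCc1ccc(F)cc1`: 3640 nM
Compound 3 `COc1cc(Oc2cccc(Nc3ccccc3)c2)cc(OC)c1CNCCNC(C)=O`: 5090 nM

Compound 3, at 5090 nM, lies within the scatter of compound 2. Its number is higher than that of compound 1, at 2180 nM, and this gap lies beyond the scatter. The next compound to be tested in this assay is compound 4 `COc1cc(Oc2cccc(Nc3ccccc3)c2)cc(OC)c1CNC(C)C`, which keeps the shared core of compound 3 and changes only the amine substituent: isopropyl in place of 2-acetamidoethyl on an amine nitrogen. In short, isopropyl stands in place of 2-acetamidoethyl on an amine nitrogen.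

For the measured compounds named here, only one measured step bears on this change. Going a 1.4-fold higher number from compound 2 to compound 3 (0.15 log units; within the scatter), acetamidomethyl replaces 4-fluorophenyl on a saturated chain carbon bound to an amine nitrogen, and that exchange stays within the scatter. Going by the values given here, compound 1 differs from the others in more than one place, so it offers no clean step. Among the compounds with values here, no measured compound carries isopropyl on this nitrogen, so the evidence is thin. With compound 2 at 3640 nM and compound 3 at 5090 nM, no shift beyond the scatter is expected in this assay.

The expected change is small, with an estimated 1.3-fold lower number from compound 3 to compound 4 (0.10 log units; within the scatter).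

For compound 4 the estimated value is 4000 nM, with an expected range of 1800 nM to 9000 nM.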

Compound 4, half-maximal inhibitory concentration: > 20000 nM
Compound 4: no number, only a limit (the forecaster's own chance of this, stated with the estimate: 8%); at least 5.0-fold (0.69 log units) between middle value and limit.
By their numbers in this assay, from the lowest: compounds 1, 2 and 3 (each within the scatter of the next, the first and the last beyond it). At a limit, above all of these: compound 4.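

In this assay the result for compound 4 is a limit of the assay and not a number: the limit of > 20000 nM in this assay, at which 1 of the 4 values shown sits.

Isopropyl on this amine nitrogen gives an at least 3.9-fold higher number from compound 3 to compound 4 (0.59 log units; beyond the scatter) in place of 2-acetamidoethyl, and an at least 5.4-fold higher number from compound 2 to compound 4 (0.73 log units; beyond the scatter) in place of 4-fluorobenzyl. The earlier exchange on this nitrogen, with a 1.4-fold higher number from compound 2 to compound 3 (0.15 log units; within the scatter), had shown only that two quite different substituents could give values within the scatter of each other, whereas compound 4 shows that a change at this position can carry inhibition in this assay well beyond the scatter, towards weaker inhibition.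

From the compounds shown here alone, the true size of both new steps stays open, as does the question of which feature of the two larger substituents separates them from isopropyl, as they share neither a ring nor an amide. Whether a longer alkyl chain such as n-butyl, a cyclohexyl ring or a simple benzyl group on this nitrogen would fall with compound 4 or with compounds 2 and 3 also remains unanswered by the compounds shown.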